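The source may hold more compounds than are shown below. What is called first, only, known or untested is meant among the compounds shown, and "the series" means these compounds.

Compound 2 `COc1ccc(CS(=O)(=O)/C=C/c2ccc([N+](=O)[O-])cc2)cc1` carries a nitro group on a six-membered aromatic ring of carbon only. In a functional assay on DU-145 cells (Homo sapiens) for antiproliferative activity, read by trypan blue exclusion (on this read-out higher numbers stand for weaker inhibition and lower numbers for stronger inhibition), compound 2 gives 7500 nM, the highest of the two numbers measured here, which on this read-out means the weaker inhibition of the pair. Its nearest neighbour is compound 1 `COc1ccc(CS(=O)(=O)/C=C/c2ccc(F)cc2)cc1`, which differs only in having a fluoro group where compound 2 has the nitro. In this assay compound 1 gives 1250 nM. That single exchange produced a 6.0-fold higher number from compound 1 to compound 2 (0.78 log units; beyond the scatter), a change beyond the usual scatter of repeated measurements. Compound 3 `COc1ccc(CS(=O)(=O)/C=C/c2ccc(N)cc2)cc1` has not yet been measured. It differs from compound 2 by amino in place of nitro on an aromatic carbon. Going by the values given here, the one measured step bears on this change only indirectly: it shows that the nitro group goes with the weaker number, but no measured pair shows what an amino group does in this place. The expectation for compound 3 in this assay therefore rests on that single step and is held wide: a number near 3000 nM, between 1000 nM and 12000 nM, is estimated. The estimate implies an expected step of a 2.5-fold lower number from compound 2 to compound 3 (0.40 log units; beyond the scatter).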

Compound 3, half-maximal inhibitory concentration: > 20000 nM
Compound 3 was reported as a limit; the forecaster's own chance of this, stated with the estimate: 5%; middle value at least 6.6-fold (0.82 log units) from the limit.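

In this assay compound 3 is reported only as a limit, not as an exact number: the limit of > 20000 nM in this assay, at which 1 of the 3 values shown sits. The earlier pair showed only that this position responds to the group it carries, with nitro giving a weaker result than fluoro, whereas the amino group now gives the weakest result of the three, with an at least 2.6-fold higher number from compound 2 to compound 3 (0.42 log units; beyond the scatter) and an at least 16-fold higher number from compound 1 to compound 3 (1.20 log units; beyond the scatter). Exchanging nitro for amino therefore does not recover any of the inhibition lost on going from fluoro to nitro, and among these three compounds the order of inhibition runs from fluoro through nitro to amino.

On these data alone, how far the true value of compound 3 lies beyond its limit remains unknown, so both steps give only a minimum size. As far as these compounds go, it is also open whether this loss belongs to the free amino group alone or would also appear with a methylamino group, an acetamido group or a hydroxyl group on the same aromatic carbon, and no cause for the loss can be drawn from these three compounds.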